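The source may report more compounds than this note shows. Statements on the series, on what has been measured and on what is new or still open speak of the compounds shown alone.

Compound 2 `COc1cc2c(cc1O)CN(CCCCNC(=O)c1ccncc1)CC2` gives 1400 nM in an assay on cells for displacement of a labelled ligand from D(4) dopamine receptor (Homo sapiens) (a lower number here means a stronger inhibitor, a higher number a weaker inhibitor), the second highest of three numbers; compound 1 `COc1cc2c(cc1O)CN(CCCCNC(=O)c1ccc(I)cc1)CC2` gives 1500 nM, and compound 3 `COc1cc2c(cc1O)CN(CCCCNC(=O)c1ccc3ccccc3c1)CC2` gives 170 nM. The step of a 1.1-fold lower number from compound 1 to compound 2 (0.03 log units; within the scatter) stays within the scatter, whereas an 8.8-fold lower number from compound 1 to compound 3 (0.95 log units; beyond the scatter) and an 8.2-fold lower number from compound 2 to compound 3 (0.92 log units; beyond the scatter) lie beyond it. Compound 4 `COc1cc2c(cc1O)CN(CCCCNC(=O)c1ccc(F)cc1)CC2` differs from compound 2 by 4-fluorophenyl in place of pyridin-4-yl on a carbonyl carbon. For the measured compounds named here, of the measured steps, only the one from compound 1 to compound 2 bears directly on this change, a swap of one six-membered aromatic group for another at the same place, and it remained within the scatter; the larger steps appeared only with naphthalen-2-yl. A step no larger than the scatter is therefore expected in this assay. Compound 4 is estimated at 1100 nM, with a range of 450 nM to 2800 nM, which is expected to mean a 1.3-fold lower number from compound 2 to compound 4 (0.10 log units; within the scatter).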

Compound 4, inhibition constant: 95 nM
The estimate for compound 4 lay 12-fold (1.06 log units) above the measured number, and the stated range ends above it.
By their numbers in this assay, from the lowest: compounds 4 and 3 (each within the scatter of the next); then compounds 2 and 1 (each within the scatter of the next).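

In this assay a single six-membered aromatic ring on the carbonyl carbon proved able to give a 15-fold lower number from compound 2 to compound 4 (1.17 log units; beyond the scatter) while a 1.8-fold lower number from compound 3 to compound 4 (0.25 log units; within the scatter) shows that naphthalen-2-yl is not needed for a number in that range. Fluoro and iodo on an aromatic carbon are also not interchangeable here, as a 16-fold lower number from compound 1 to compound 4 (1.20 log units; beyond the scatter) makes plain. No measurement shown explains these steps. As far as these compounds go, whether unsubstituted phenyl or 4-chlorophenyl would fall with the fluoro or with the iodo compound stays open. So does whether the 4-fluorophenyl gain would hold with a longer chain.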